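Cytotoxicity notes on compound 1, compound 2, compound 3, compound 4

The source may hold more compounds than are shown below. What is called first, only, known or untested is meant among the compounds shown, and "the series" means these compounds.

Measured so far in an ADME assay on HFF cells (Homo sapiens) for cytotoxicity, with a stated time of 8 days; a lower number here means that less compound is tolerated, a higher number that more compound is tolerated:
compound 1 `Nc1nc(NC2CCCCC2)c2ncn(/C=C3/CC3(CO)CO)c2n1` gives a limit, > 300000 nM.
compound 2 `CCCNc1nc(N)nc2c1ncn2/C=C1/CC1(CO)CO` gives a limit, > 300000 nM.
compound 3 `CCCCCOc1nc(N)nc2c1ncn2/C=C1/CC1(CO)CO` gives 259000 nM.

Compound 1 stands at the ceiling of this assay; its value is a limit, not a number, and two of the three values shown sit there (the limit of > 300000 nM in this assay, at which 2 of the 3 values shown sit). Compound 4 `Nc1nc(SCc2ccccc2)c2ncn(/C=C3/CC3(CO)CO)c2n1` differs from compound 1 by benzylsulfanyl in place of cyclohexylamino on an aromatic carbon. The steps that touch the same position are a step that the two limits leave unreadable from compound 1 to compound 2 and an at least 1.1-fold lower number from compound 1 to compound 3 (0.06 log units; that floor lies within the scatter), the latter within the scatter, so neither reports a readable change. For the measured compounds named here, no measured step exchanges an amine for a sulfur-linked group. For compound 4 the expected step is therefore an at least 1.2-fold lower number from compound 1 to compound 4 (0.07 log units; that floor lies within the scatter), with no change beyond the scatter. Compound 4 is estimated at 250000 nM, between 100000 nM and 300000 nM.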

Compound 4, half-maximal cytotoxic concentration: > 300000 nM
Compound 4 was reported as a limit; the forecaster's own chance of this, stated with the estimate: 60%; at least 1.2-fold (0.07 log units) between middle value and limit.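

In this assay, compound 4 gives a limit, so benzylsulfanyl, with a sulfur link and an aromatic ring, joins the two amine-linked groups at this position at the ceiling: the limit of > 300000 nM in this assay, at which 3 of the 4 values shown sit. For the compounds shown here, the steps from the two amine-linked compounds cannot be read, and the one readable step is an at least 1.1-fold higher number from compound 3 to compound 4 (0.06 log units; that floor lies within the scatter), so this change separates benzylsulfanyl from pentyloxy by nothing beyond the scatter.

Open, on these data alone, is whether any group here gives a measured value clearly lower than these. A carboxylic acid or a longer alkylamine chain on this aromatic carbon could test this.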